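A few compounds are considered here, and "the series" means these few. Any claim that something is new, unique, unknown or untested is made for them only; others in the source may bear on it.

Compound 1 `O=C(Cn1c(=O)oc2cc(Cl)ccc21)Nc1nc2ccc([N+](=O)[O-])cc2s1`, compound 2 `O=C(Cn1c(=O)oc2cc([N+](=O)[O-])ccc21)Nc1nc2ccc([N+](=O)[O-])cc2s1` and compound 3 `O=C(Cn1c(=O)oc2cc([N+](=O)[O-])ccc21)NCc1ccccn1` have each been tested in an ADME assay on RAW264.7 cells (Mus musculus) for cytotoxicity, read by MTT assay, with a stated time of 72 h, tested at 50 uM; on this read-out lower numbers stand for a weaker effect and higher numbers for a stronger effect at the one concentration tested. In this assay compound 1 gives 12.5%, compound 2 gives 14.8% and compound 3 gives 21.8%, and these three numbers all lie within the usual scatter of one another. Compound 2 and compound 1 differ in one place only, (chloro in place of nitro on an aromatic carbon), and that change made a step of a number 2.3 percentage points lower from compound 2 to compound 1 (within the scatter). The difference between the cores of compound 2 and compound 3 is not broken down here. Compound 4 `O=C(Cn1c(=O)oc2cc(Cl)ccc21)NCc1ccccn1` has not yet been measured; it differs from compound 3 by the same change, (chloro in place of nitro on an aromatic carbon). A small step of a number 2.3 percentage points lower from compound 3 to compound 4 (within the scatter) is expected, because the earlier step of a number 2.3 percentage points lower from compound 2 to compound 1 (within the scatter) stayed within the scatter. Compound 4 is therefore estimated at 19.5%, expected between 10% and 30%.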

Compound 4, a percentage reported as inhibition, at one concentration (the size of the read-out at that concentration, not a potency): 36.2%
The estimate for compound 4 lay 16.7 percentage points below the measured number; measured number outside the range, above it.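

In this assay, putting chloro in place of nitro on an aromatic carbon gave a step of a number 14.4 percentage points higher from compound 3 to compound 4 (beyond the scatter). The same change therefore did not carry the same result from one core to the other: the same change on two cores in this assay, a number 2.3 percentage points lower (within the scatter) from compound 2 to compound 1 and a number 14.4 percentage points higher (beyond the scatter) from compound 3 to compound 4, 16.7 percentage points apart, beyond the scatter of two such steps

This shows that, for these two pairs, a step seen on one core was a poor guide to the step on the other, but it does not show which part of the cores accounts for the gap or what the change would do on a third core. The compounds shown leave open how an amine or a methoxy group on that same aromatic carbon would compare with chloro and nitro on each core.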